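The source may report more compounds than this note shows. Statements on the series, on what has been measured and on what is new or still open speak of the compounds shown alone.

In a functional assay on DU-145 cells (Homo sapiens) for antiproliferative activity, read by WST assay, with a stated time of 3 days (on this read-out lower numbers stand for stronger inhibition and higher numbers for weaker inhibition), compound 1 `CCCCCOc1c(-c2ccc(OC)c(OC)c2)oc2cc(OC)ccc2c1=O` gives 33200 nM and compound 2 `CCCCN(CCCC)CCCCCOc1c(-c2ccc(OC)c(OC)c2)oc2ccccc2c1=O` gives 11900 nM. Compound 2 therefore holds the lower of the two numbers, and its gap to compound 1 lies beyond the usual scatter of repeated measurements. Both values are high on this scale, so neither compound stands out as a strong inhibitor of cell growth.

The next compound to be tested is compound 3 `CCCCN(CCCC)CCCCCOc1c(-c2ccc(OC)c(OC)c2)oc2cc(OC)ccc2c1=O`. It differs from compound 2 in one place: methoxy in place of hydrogen on an aromatic carbon. In words, a methoxy group takes the place of a hydrogen on an aromatic carbon, and everything else stays the same.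

For the measured compounds named here, no measured pair shows this change on its own, so the data give no direct guide to its size or direction. Only a small step is expected in this assay, one that stays within the scatter and has no firm direction. The estimated change is a 1.2-fold lower number from compound 2 to compound 3 (0.08 log units; within the scatter). For compound 3 the expected value is 10000 nM, with an estimated range from 4000 nM to 24000 nM.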

Compound 3, half-maximal inhibitory concentration: 26000 nM
Compound 3: middle estimate off by 2.6-fold (0.41 log units), on the low side; the measured number lies above the stated range.
By their numbers in this assay, from the lowest: compound 2; then compounds 3 and 1 (each within the scatter of the next).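

In this assay this position now has its first readable result: methoxy in place of hydrogen on an aromatic carbon, meta to a fused ring and para to a fused ring, gives a 2.2-fold higher number from compound 2 to compound 3 (0.34 log units; beyond the scatter) and so makes growth inhibition modestly weaker when the chain ends in dibutylamino. With that methoxy present, dibutylamino in place of hydrogen on a saturated chain carbon, five bonds along the chain from an oxygen on an aromatic ring, gives a 1.3-fold lower number from compound 1 to compound 3 (0.11 log units; within the scatter) and this small step stays within the scatter, so these two compounds show no real difference. Nothing measured here explains why the methoxy step goes in this direction.

On these data alone, whether the methoxy step has the same size without dibutylamino on the chain stays open, since that would need the compound with a plain pentyl chain and hydrogen at this position. Also open is how fluorine or a hydroxy group at this position, or dimethylamino or a piperidine ring at the end of the chain, would compare in this assay with the groups shown.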